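A few compounds are considered here, and "the series" means these few. Any claim that something is new, unique, unknown or untested is made for them only; others in the source may bear on it.

Measured in an ADME assay on MT4 cells (Homo sapiens) for cytotoxicity, read by MTT assay, with a stated time of 4 days (a lower number here means that less compound is tolerated, a higher number that more compound is tolerated), are three compounds, each only as a limit:
- compound 1 `CN(C)c1nc(Cc2c(F)cccc2F)cc(=O)[nH]1` gives > 94000 nM (a limit)
- compound 2 `O=c1cc(Cc2c(F)cccc2F)nc(-n2cccc2)[nH]1` gives > 87000 nM (a limit)
- compound 3 `Cc1c(Cc2c(F)cccc2F)nc(N(C)C)[nH]c1=O` gives > 89000 nM (a limit)

Compound 3 therefore stands at a limit, and none of the three compounds has a readable number. Compound 4 `Cc1c(Cc2c(F)cccc2F)nc(N(C)C(C)C)[nH]c1=O` carries isopropyl in place of methyl on a nitrogen on an aromatic ring. For the measured compounds named here, two measured steps bear on this change: the replacement of dimethylamino (a step that the two limits leave unreadable from compound 1 to compound 2) and the added methyl (a step that the two limits leave unreadable from compound 1 to compound 3). Neither gives a size, so no step beyond the scatter is expected in this assay here. The estimated change is an at least 1.1-fold lower number from compound 3 to compound 4 (0.04 log units; that floor lies within the scatter) and another limit is likely. The estimate for compound 4 is 80000 nM (expected range 30000 nM to 100000 nM).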

Compound 4, half-maximal cytotoxic concentration: 79000 nM
The estimate for compound 4 lay 1.0-fold (0.01 log units) above the measured number; the measured number falls inside the stated range.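

In this assay, for the compounds shown here, compound 4 gives 79000 nM as the first readable number of the series, while the steps among the earlier compounds cannot be read. Isopropyl in place of methyl on a nitrogen on an aromatic ring gives an at least 1.1-fold lower number from compound 3 to compound 4 (0.05 log units; that floor lies within the scatter) and so marks the first change at this nitrogen with a lower bound on its size. Compound 3 remains a limit: the limit of > 89000 nM in this assay, at which 1 of the 4 values shown sits.

From the compounds shown here alone, the full size of this step therefore stays open. Also open, going by these compounds, is whether a longer chain or a cyclopropyl group on this nitrogen would lower the number further.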